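Swapping iodo for methoxy on a growth-inhibiting amide

This account rests on a few compounds, and the source may have more. Where it says the series, first, only, none or still open, it means among the compounds named here.

Measured in a functional assay on COLO 205 cells (Homo sapiens) for inhibition; on this read-out higher numbers stand for weaker inhibition of growth and lower numbers for stronger inhibition of growth:
- Compound 1 `NC(=O)c1cc(Cl)ccc1NC(=O)COc1ccccc1`: 2510 nM
- Compound 2 `NC(=O)c1cc(I)ccc1NC(=O)COc1ccccc1`: 353 nM

Of these two compounds, compound 2 has the lower number, at 353 nM, so it inhibits growth more strongly. Compound 3 `COc1ccc(NC(=O)COc2ccccc2)c(C(N)=O)c1` has not yet been measured. It carries methoxy in place of iodo on an aromatic carbon, meta to a carbamoyl group and para to a large group (methoxy in place of iodo on an aromatic carbon).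

Within the data shown here, only one measured step bears on this change. It is a 7.1-fold lower number from compound 1 to compound 2 (0.85 log units; beyond the scatter), which lies beyond the scatter and also swaps the group on an aromatic carbon. Neither measured compound carries methoxy, so that step offers a guide to size but no direct reading. Compound 2 holds the lower of just two numbers, so a move away from iodo is expected to raise the number in this assay, by a step of similar size.

The expected change is a 7.1-fold higher number from compound 2 to compound 3 (0.85 log units; beyond the scatter), though this estimate is uncertain. For compound 3 the estimated value is 2500 nM, with an expected range from 700 nM to 9000 nM.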

Compound 3, concentration for 50% growth inhibition: 487 nM
Compound 3: the middle estimate sits 5.1-fold (0.71 log units) above what was measured; the measured number lies below the stated range.
By their numbers in this assay, from the lowest: compounds 2 and 3 (each within the scatter of the next); then compound 1.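

In this assay there is a 1.4-fold higher number from compound 2 to compound 3 (0.14 log units; within the scatter) and that step stays within the scatter, so at this aromatic carbon methoxy and iodo cannot be told apart, even though iodo is a single iodine atom while methoxy brings a carbon, an oxygen and a hydrogen-bond acceptor. Against chloro there is a 5.2-fold lower number from compound 1 to compound 3 (0.71 log units; beyond the scatter) and this step lies beyond the scatter, so chloro now stands apart from two different groups rather than one, and the lower numbers at this position are no longer tied to iodo alone. Nothing measured here explains why chloro gives a higher number than the other two groups.

Going by these compounds, it remains open whether other groups at this same carbon, such as an amine, a carboxylic acid or a longer chain like ethoxy, would give numbers close to those of compound 2 and compound 3 or closer to that of compound 1. On these data alone, it is also open whether the same ranking of these three groups would hold if another part of the shared core were changed.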